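Azetidinyl to thienyl on the ring of compound 3

This account rests on a few compounds, and the source may have more. Where it says the series, first, only, none or still open, it means among the compounds named here.

Going by the values given here, compound 3 `Clc1cccc(-n2ncnc2NCc2cccnc2N2CCC2)c1Cl` gives 25.7 nM in a functional assay for antagonist activity at P2X purinoceptor 7 (Rattus norvegicus), read by FLIPR and calcium flux (a lower number here means a stronger inhibitor, a higher number a weaker inhibitor), the lowest of the three numbers so far; compound 2 `Clc1cccc(-n2ncnc2NCc2ccccc2)c1Cl` gives 209 nM and compound 1 `Clc1cccc(-n2ncnc2Nc2ccccc2)c1Cl` gives 3890 nM. Compound 4 `Clc1cccc(-n2ncnc2NCc2cccnc2-c2ccsc2)c1Cl` differs from compound 3 by thiophen-3-yl in place of azetidin-1-yl on an aromatic carbon. Among the compounds with values here, the only step measured, a 19-fold lower number from compound 1 to compound 2 (1.27 log units; beyond the scatter), concerns the group on the ring nitrogen, not the position changed here, so no measured step bears on this change. With no guide from the data, a step within the scatter is expected: for compound 4 the estimate is 40 nM, with a range from 10 nM to 160 nM. This estimate means an expected step of a 1.6-fold higher number from compound 3 to compound 4 (0.19 log units; within the scatter).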

Compound 4, half-maximal inhibitory concentration: 138 nM
For compound 4 the middle estimate is 3.5-fold (0.54 log units) below the measured one, within the range that was stated.
By their numbers in this assay, from the lowest: compound 3; then compounds 4 and 2 (each within the scatter of the next); then compound 1.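

In this assay the place next to the ring nitrogen proves sensitive to the group it carries, as thiophen-3-yl in place of azetidin-1-yl moves the series the wrong way (a 5.4-fold higher number from compound 3 to compound 4 (0.73 log units; beyond the scatter)). The earlier compounds shown here gave no step at this place. Nothing measured here accounts for the loss.

The change swaps a four-membered non-aromatic ring for a five-membered aromatic ring, and the compounds shown do not separate ring size from aromaticity. Open, as far as these compounds go, is how a pyrrolidin-1-yl ring, a phenyl ring or an open-chain dimethylamino group would read at this place.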